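The compounds below may be only part of what the source reports. "The series", "measured", "known", "first", "only" and "open" are said of these compounds alone.

Measured so far:
compound 1, `CCS(=O)(=O)N1CC2CCC(NC(=O)c3ccc(Cl)cc3Cl)C2C1`; in an assay on isolated protein for inhibition of sodium- and chloride-dependent glycine transporter 1 (Homo sapiens) (a higher number here means a weaker inhibitor, a lower number a stronger inhibitor), compound 1 gives > 10000 nM, a limit of the assay.
compound 2, `CCCS(=O)(=O)N1CC2CCC(NC(=O)c3ccc(Cl)cc3Cl)C2C1`; in this assay compound 2 gives > 10000 nM, again a limit.
compound 3, `Cn1cnc(S(=O)(=O)N2CC3CCC(NC(=O)c4ccccc4C(F)(F)F)C3C2)c1`; in this assay compound 3 gives 112000 nM.

Among the compounds with values here, compound 3 thus holds the only value that is reported as a number; the other two sit at the limit of > 10000 nM in this assay, at which 2 of the 3 values shown sit, so it cannot be placed in order against them. Its own number marks it as a very weak inhibitor. Within the data shown here, the one step between measured compounds, a step that the two limits leave unreadable from compound 1 to compound 2, cannot be read in size, and it concerns a sulfonyl chain rather than the benzamide ring.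

Compound 4, `Cn1cnc(S(=O)(=O)N2CC3CCC(NC(=O)c4ccccc4F)C3C2)c1`, has not yet been measured. It differs from compound 3 by fluoro in place of trifluoromethyl on an aromatic carbon. Among the measured compounds shown here, no measured step touches this part of the molecule, so the measured data give no guidance on the direction or size of the change; the only anchor is the weak value of compound 3, 112000 nM.

On that basis compound 4 is estimated at 90000 nM, with a range from 15000 nM to 400000 nM. The step of a 1.2-fold lower number from compound 3 to compound 4 (0.09 log units; within the scatter) is therefore expected to stay within the scatter, with a fair chance that the assay reports only a limit.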

Compound 4, half-maximal inhibitory concentration: 1820000 nM
Beside the measured number, compound 4's estimate is 20-fold (1.31 log units) below it; measured number outside the range, above it.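

In this assay, within the data shown here, the change from 2-(trifluoromethyl)phenyl to 2-fluorophenyl gives the only readable step so far (a 16-fold higher number from compound 3 to compound 4 (1.21 log units; beyond the scatter)). Among these compounds, it shows that the group on this aromatic carbon, ortho to a large group, does move the read-out, whereas the earlier compounds offered only one step, on a sulfonyl chain, which the two limits leave unreadable. With everything else in the molecule held the same, trifluoromethyl goes with the lower number and fluoro with the higher, though both compounds remain very weak inhibitors, and nothing measured here accounts for the size of this step.

On these data alone, it remains open where hydrogen, chloro, methoxy or a nitrile on this same aromatic carbon would fall relative to compound 3 and compound 4, and whether trifluoromethyl would go with the lower number on another carbon of the ring. Also open, as far as these compounds go, is how an amine or a carboxylic acid on this ring would read, and whether any such change would carry over to a different sulfonyl group.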